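The compounds below may be only part of what the source reports. "The series", "measured", "known", "first", "only" and "open" are said of these compounds alone.

Measured so far in an assay on microsomes from brain for inhibition of Fatty-acid amide hydrolase 1 (Rattus norvegicus), read by fluorescence and HPLC, with a stated time of 60 min; a higher number here means a weaker inhibitor, a lower number a stronger inhibitor:
compound 1 `CCCCCCCCc1ccc(OCC(=O)Cn2nnc(C)n2)cc1`, 27 nM
compound 2 `CCCCCCCCc1ccc(OCC(=O)Cn2nnc(-c3ccc(Cl)cc3)n2)cc1`, 35 nM
compound 3 `CCCCCCCCc1ccc(OCC(=O)Cn2nnc(Cc3ccccc3)n2)cc1`, 66 nM

Compound 3 gives the highest number of the three; it lies a 1.9-fold higher number from compound 2 to compound 3 (0.28 log units; within the scatter) and a 2.4-fold higher number from compound 1 to compound 3 (0.39 log units; beyond the scatter). The unmeasured compound 4 `CCCCCCCCc1ccc(OCC(=O)Cn2nnc(CCC(=O)O)n2)cc1` differs from compound 3 by carboxymethyl in place of phenyl on a saturated chain carbon bound to an aromatic carbon. The steps that touch this position are small: a 2.4-fold higher number from compound 1 to compound 3 (0.39 log units; beyond the scatter) and a 1.9-fold higher number from compound 2 to compound 3 (0.28 log units; within the scatter), while a 1.3-fold higher number from compound 1 to compound 2 (0.11 log units; within the scatter). For the measured compounds named here, nothing measured here carries a carboxylic acid or any hydrogen-bond donor at this position, so the step is only loosely anchored; all variation at this position so far has stayed within a modest span. A modest further rise in this assay is expected, a 1.7-fold higher number from compound 3 to compound 4 (0.22 log units; within the scatter). Compound 4 is estimated at 110 nM, with a range from 35 nM to 350 nM.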

Compound 4, half-maximal inhibitory concentration: 30 nM
Estimate against measurement, compound 4: 3.7-fold (0.56 log units) above, and the stated range ends above it.
By their numbers in this assay, from the lowest: compounds 1, 4, 2 and 3 (each within the scatter of the next, the first and the last beyond it).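

In this assay carboxymethyl in place of phenyl on the saturated chain carbon gives a 2.2-fold lower number from compound 3 to compound 4 (0.34 log units; beyond the scatter) and brings a hydrogen-bond donor to a position that had held none. With a 1.1-fold higher number from compound 1 to compound 4 (0.05 log units; within the scatter) and a 1.2-fold lower number from compound 2 to compound 4 (0.07 log units; within the scatter) both within the scatter, the carboxylic acid chain stands level with methyl and 4-chlorophenyl, so this position accepts the acid without loss. Nothing at hand accounts for this tolerance. Open, from the compounds shown here alone, is whether a methyl ester, a primary amide or an amine holds the same level here, and whether a longer chain ending in a carboxylic acid does too.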